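This account rests on a few compounds, and the source may have more. Where it says the series, first, only, none or still open, it means among the compounds named here.

Measured compounds:
Compound 1 `COc1ccc(Cl)cc1C(=O)NCCC1CCN(S(=O)(=O)NC(=O)NC2CCCCC2)CC1`: 25% in a functional assay on the whole organism (blood) with Rattus norvegicus as the target, with stated times of 24 h and 1 h, at a dose of 5 mg/kg by the intraperitoneal route; on this read-out higher numbers stand for a stronger effect at the one dose given and lower numbers for a weaker effect
Compound 2 `CCCNC(=O)NS(=O)(=O)N1CCC(CCNC(=O)c2cc(Cl)ccc2OC)CC1`: 11%
Compound 3 `COc1ccc(Cl)cc1C(=O)NCCC1CCN(S(=O)(=O)NC(=O)NC[C@@H]2C[C@@H]3CC[C@@H]2O3)CC1`: 30%

Among these three values compound 1 stands second highest. Its gap to compound 3 is small, a number 5 percentage points higher from compound 1 to compound 3 (within the scatter), so the two cannot be told apart, whereas the step from compound 1 to compound 2 is clear, a number 14 percentage points lower from compound 1 to compound 2 (beyond the scatter). Among the compounds with values here, both of these steps, and the one from compound 2 to compound 3 a number 19 percentage points higher from compound 2 to compound 3 (beyond the scatter), alter only the group on the amide-type nitrogen at the urea end of the shared core.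

Compound 4 `O=C(NC1CCCCC1)NS(=O)(=O)N1CCC(CCNC(=O)C(F)(F)F)CC1` differs from compound 1 at the opposite end: trifluoromethyl in place of 5-chloro-2-methoxyphenyl on a carbonyl carbon. Within the data shown here, no measured step touches this carbonyl end, so the effect of the change is not foreshadowed by any measured pair, and the estimate rests on compound 1 alone. The change removes a ring entirely and replaces it with a much smaller group, and with nothing to compare it to the expectation is kept wide.

Compound 4 is therefore expected to give about 12%, within the range 0% to 28%, an expected step of a number 13 percentage points lower from compound 1 to compound 4 (beyond the scatter).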

Compound 4, a percentage reported as activity, at one dose (the size of the read-out at that dose, not a potency): 13%
Compound 4: the middle estimate sits 1 percentage points below what was measured; the range from low to high includes it.
By their numbers in this assay, from the lowest: compounds 2 and 4 (each within the scatter of the next); then compounds 1 and 3 (each within the scatter of the next).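

In this assay, the carbonyl end of the molecule now has a measured step of its own: trifluoromethyl in place of 5-chloro-2-methoxyphenyl gives a number 12 percentage points lower from compound 1 to compound 4 (beyond the scatter). So this end of the shared core can change the read-out, as the group on the urea end already did, and with the ring gone compound 4 still gives 13%, so in this one pair the effect falls without vanishing. No supporting measurement bears on why the number drops.

This single pair cannot separate the loss of the ring from the loss of its chlorine or methoxy group, and a plain phenyl on the same carbonyl carbon would speak to that. It also leaves open whether trifluoromethyl would give a similar step alongside the propyl group of compound 2.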